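Aryl swap on the triazole nitrogen: compound 2 to compound 3

This account rests on a few compounds, and the source may have more. Where it says the series, first, only, none or still open, it means among the compounds named here.

Measured so far:
compound 1 `N#CC1=C(N)Oc2c(c3nc4ccccc4nc3c3ccccc23)C12C(=O)N(Cc1cnnn1-c1ccc(Br)cc1)c1ccccc12` — 36600 nM
compound 2 `Cc1cc(C)cc(-n2nncc2CN2C(=O)C3(C(C#N)=C(N)Oc4c3c3nc5ccccc5nc3c3ccccc43)c3ccccc32)c1` — a limit only

In a functional assay on MCF7 cells (Homo sapiens) for antiproliferative activity, read by MTT assay, with a stated time of 48 h (on this read-out lower numbers stand for stronger inhibition and higher numbers for weaker inhibition), compound 1 gives 36600 nM. For compound 2 the result is only a limit of the assay, > 50000 nM. For the measured compounds named here, the sole measured step, an at least 1.3-fold higher number from compound 1 to compound 2 (0.13 log units; that floor lies within the scatter), runs into that limit (the limit of > 50000 nM in this assay, at which 1 of the 2 values shown sits). Compound 3 `Cc1ccc(Cl)cc1-n1nncc1CN1C(=O)C2(C(C#N)=C(N)Oc3c2c2nc4ccccc4nc2c2ccccc32)c2ccccc21` carries the change (5-chloro-2-methylphenyl in place of 3,5-dimethylphenyl on an aromatic nitrogen). Going by the values given here, no measured step exchanges these two groups, so the 4-bromophenyl analogue compound 1 is the only other anchor. Compound 3 is expected near the limit, with an at least 1.1-fold lower number from compound 2 to compound 3 (0.04 log units; that floor lies within the scatter). The estimate for compound 3 is 45000 nM, within 18000 nM to 110000 nM.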

Compound 3, half-maximal inhibitory concentration: > 50000 nM
Compound 3: no number, only a limit; the forecaster's own chance of this, stated with the estimate: 50%; at least 1.1-fold (0.04 log units) between middle value and limit.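

In this assay, a chlorine-bearing, ortho-free wording aside, compound 3 shows that 5-chloro-2-methylphenyl on this aromatic nitrogen also ends at a limit rather than a number. The only readable result is an at least 1.3-fold higher number from compound 1 to compound 3 (0.13 log units; that floor lies within the scatter), and the step from compound 2 to compound 3 cannot be read. The replacements of 4-bromophenyl at this position now both end at the same limit: the limit of > 50000 nM in this assay, at which 2 of the 3 values shown sit.

From the compounds shown here alone, whether any aryl group here gives a number clearly lower than that of compound 1 stays open. So does the outcome of an amine or a carboxylic acid on the phenyl ring.

Correction to the first sentence, which should read: In this assay, compound 3 shows that 5-chloro-2-methylphenyl on this aromatic nitrogen also ends at a limit rather than a number.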